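The source may hold more compounds than are shown below. What is called first, only, known or untested is meant among the compounds shown, and "the series" means these compounds.

Measured compounds: compound 1, `CCCc1nn(C)c2c(NC(C)C)nc(/C=C/c3nc(C)c(C)nc3C)nc12`, 342000 nM; compound 2, `COc1cc(/C=C/c2nc(N3CCN(C)CC3)c3sccc3n2)cc(OC)c1OC`, > 1000000 nM.

In a functional assay on L02 cells (Homo sapiens) for inhibition, read by Griess assay, with stated times of 1 h and 24 h (on this read-out lower numbers stand for stronger inhibition and higher numbers for weaker inhibition), compound 1 gives 342000 nM. In this assay compound 2 is known only as a limit, > 1000000 nM, so compound 2 stands at the limit of the assay (the limit of > 1000000 nM in this assay, at which 1 of the 2 values shown sits), with no number behind it. Compound 3, `COc1cc(/C=C/c2nc(NCc3ccco3)c3sccc3n2)cc(OC)c1OC`, has not yet been measured; it differs from compound 2 by ((furan-2-yl)methyl)amino in place of 4-methylpiperazin-1-yl on an aromatic carbon. Going by the values given here, no step between measured compounds is available to guide the expectation. The estimated step of an at least 1.6-fold lower number from compound 2 to compound 3 (0.22 log units; that floor lies within the scatter) is expected to lie within the usual scatter, in no clear direction. Compound 3 is therefore estimated to give 600000 nM, between 100000 nM and 3000000 nM.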

Compound 3, half-maximal inhibitory concentration: 189000 nM
Estimate against measurement, compound 3: 3.2-fold (0.50 log units) above; the range from low to high includes it.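

In this assay, ((furan-2-yl)methyl)amino in place of 4-methylpiperazin-1-yl on this aromatic carbon gives an at least 5.2-fold lower number from compound 2 to compound 3 (0.72 log units; beyond the scatter), so the position responds to this change. From the compounds shown here alone, the true size of the step stays unknown, because compound 2 is known only as a limit: the limit of > 1000000 nM in this assay, at which 1 of the 3 values shown sits.

The compounds shown leave open whether the furan ring or the amino hydrogen goes with the step. A benzylamino group or a plain methylamino group at the same place would be needed to separate the two.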